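Benzimidazole in place of methylimidazole: a solubility forecast

The compounds below may be only part of what the source reports. "The series", "measured", "known", "first", "only" and "open" are said of these compounds alone.

In a physicochemical assay for solubility, at pH 7.4 (on this read-out lower numbers stand for lower solubility and higher numbers for higher solubility), compound 3 `Cc1cc(C)c(-c2cn(C)cn2)cc1NC(=O)c1ccc(OCc2ccccn2)cc1` gives 8000 nM, the second highest of the three numbers measured. Compound 1 `Cc1cc(Cl)c(-c2cn(C)cn2)cc1NC(=O)c1ccc(OCc2ccccn2)cc1` gives 20000 nM in this assay, and compound 2 `Cc1cc(C)c(-c2ncc[nH]2)cc1NC(=O)c1ccc(OCc2ccccn2)cc1` gives 2000 nM. Two steps connect them: a 2.5-fold lower number from compound 1 to compound 3 (0.40 log units; beyond the scatter) came with methyl in place of chloro, and a 4.0-fold higher number from compound 2 to compound 3 (0.60 log units; beyond the scatter) came with 1-methyl-1H-imidazol-4-yl in place of 1H-imidazol-2-yl. Compound 4 `Cc1cc(C)c(-c2nc3ccccc3[nH]2)cc1NC(=O)c1ccc(OCc2ccccn2)cc1` differs from compound 3 by 1H-benzimidazol-2-yl in place of 1-methyl-1H-imidazol-4-yl on an aromatic carbon. Among the measured compounds shown here, the second step bears on this change most, since the incoming 1H-benzimidazol-2-yl resembles the 1H-imidazol-2-yl of compound 2 in its five-membered aromatic ring with 2 hetero atoms; the added six-membered aromatic ring of carbon only is covered by no measured step, so the forecast is wider. Compound 4 is expected to give a lower number than compound 3, a step of about a 10-fold lower number from compound 3 to compound 4 (1.00 log units; beyond the scatter). Compound 4 is estimated at 800 nM in this assay, with a range from 200 nM to 3000 nM.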

Compound 4, solubility: < 1000 nM
Compound 4 ended at the assay's limit; the forecaster's own chance of this, stated with the estimate: 10%; the middle value is on the limit's open side.
By their numbers in this assay, from the lowest: compound 2; then compound 3; then compound 1. At a limit, below all of these: compound 4.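

In this assay the reading for compound 4 is a limit of the assay, not a number: the limit of < 1000 nM in this assay, at which 1 of the 4 values shown sits.

Among the compounds shown here, on this aromatic carbon, 1H-benzimidazol-2-yl in place of 1-methyl-1H-imidazol-4-yl brought an at least 8.0-fold lower number from compound 3 to compound 4 (0.90 log units; beyond the scatter), so this position tolerates a change that takes the read-out to the assay's limit, which no earlier compound reached. Set against the 1H-imidazol-2-yl of compound 2, the same group brought an at least 2.0-fold lower number from compound 2 to compound 4 (0.30 log units; that floor lies within the scatter), so the added six-membered aromatic ring of carbon only cannot yet be said to separate compound 4 from compound 2.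

On these data alone, the true value of compound 4 stays open, and with it the size of both steps. Also open, as far as these compounds go, is whether an amine or a carboxylic acid on that added ring would move the number back towards that of compound 3.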